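Working notes: from 4-fluorophenyl to 4-chlorophenyl

The compounds below may be only part of what the source reports. "The series", "measured", "known", "first", "only" and "open" are said of these compounds alone.

compound 1 `COc1ccc(-c2noc(C3CCCN3)n2)cc1OC1CCCC1` 43 nM
compound 2 `COc1ccc(-c2noc(Cc3c[nH]c4ccccc34)n2)cc1OC1CCCC1` > 1000000 nM
compound 3 `COc1ccc(-c2noc(-c3ccc(F)cc3)n2)cc1OC1CCCC1` 87900 nM

All values come from a functional assay on LNCaP cells (Homo sapiens) for antiproliferative activity, read by MTT assay, with a stated time of 24 h (on this read-out lower numbers stand for stronger inhibition and higher numbers for weaker inhibition), and are half-maximal inhibitory concentrations. For compound 2 the entry > 1000000 nM is a limit of the assay and not a number. Of the two true numbers, compound 3 holds the higher one, and the measured step that reaches it is large (with a 2000-fold higher number from compound 1 to compound 3 (3.31 log units; beyond the scatter)). Compound 4 `COc1ccc(-c2noc(-c3ccc(Cl)cc3)n2)cc1OC1CCCC1` differs from compound 3 in one place (by chloro in place of fluoro on an aromatic carbon), with chloro in place of fluoro on an aromatic carbon, para to a large group. Within the data shown here, the only measured step (of a 2000-fold higher number from compound 1 to compound 3 (3.31 log units; beyond the scatter)) is a different exchange, 4-fluorophenyl in place of pyrrolidin-2-yl, so its size does not carry over, and no measured step exchanges one halogen for another. No step beyond the scatter is therefore expected in this assay, and no direction is favoured with any confidence. The expected step is small (namely a 1.1-fold lower number from compound 3 to compound 4 (0.04 log units; within the scatter)). The estimate for compound 4 is 80000 nM (expected range 20000 nM to 300000 nM).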

Compound 4, half-maximal inhibitory concentration: 20800 nM
The estimate for compound 4 lay 3.8-fold (0.59 log units) above the measured number; measured number inside the range.
By their numbers in this assay, from the lowest: compound 1; then compound 4; then compound 3. At a limit, above all of these: compound 2.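

In this assay the exchange of one halogen for another on an aromatic carbon, para to a large group, is not silent: chloro in place of fluoro gives a 4.2-fold lower number from compound 3 to compound 4 (0.63 log units; beyond the scatter) and so shows that this position responds to the halogen it carries. The gain remains small beside the distance to the pyrrolidin-2-yl compound, with a 480-fold higher number from compound 1 to compound 4 (2.68 log units; beyond the scatter) still separating the two, so 4-chlorophenyl recovers only part of what the aryl replacement loses. Nothing measured here gives a reason for the size of either step.

As far as these compounds go, two halogens make no trend, so it remains open whether bromo or methoxy in the same place would give a lower or a higher number. Also open, from the compounds shown here alone, is whether the gap to compound 1 narrows with another amine in place of the 4-chlorophenyl group, such as piperidin-2-yl.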